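From cyclohexyl to tert-butyl on a shared core

The source may report more compounds than this note shows. Statements on the series, on what has been measured and on what is new or still open speak of the compounds shown alone.

Of the compounds shown here, three sharing one core have been tested in a functional assay on HL-60 cells (Homo sapiens) for inhibition, read by MTT assay, with a stated time of 72 h (a lower number here means a stronger inhibitor, a higher number a weaker inhibitor), so far. Among the compounds with values here, compound 1 (`CCc1nc(-c2ccccc2F)c(C(=O)N2CCN(c3cccc(Cl)c3)CC2)o1`) gives 139 nM and is the only one with a number. Compound 2 (`O=C(c1oc(C(F)(F)F)nc1-c1ccccc1F)N1CCN(c2cccc(Cl)c2)CC1`) is recorded as "not active" (no number reported) with no number reported. Compound 3 (`O=C(c1oc(C2CCCCC2)nc1-c1ccccc1F)N1CCN(c2cccc(Cl)c2)CC1`) is likewise recorded as "not active" (no number reported) with no number reported. Compound 3 therefore has no place on the numerical scale and stands with compound 2 as the one other entry without a single number.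

Compound 4 (`CC(C)(C)c1nc(-c2ccccc2F)c(C(=O)N2CCN(c3cccc(Cl)c3)CC2)o1`) carries tert-butyl in place of cyclohexyl (tert-butyl in place of cyclohexyl on an aromatic carbon) on an aromatic carbon of a five-membered aromatic ring with 1 nitrogen and 1 oxygen. No size can be put on this step in this assay since compound 3 offers no number to start from. The expected direction is toward measurable inhibition, but only tentatively. Compound 1 at 139 nM is the sole numerical reference, and compound 4 is expected to be a weaker inhibitor than that. A result of no activity also remains quite possible. For compound 4 the estimated half-maximal inhibitory concentration is 1500 nM with an expected range from 200 nM to 10000 nM if a number is reported at all.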

Compound 4, half-maximal inhibitory concentration: > 1000 nM
Compound 4: a limit, no number; the forecaster's own chance of this, stated with the estimate: 45%; the middle value does not contradict the limit.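

In this assay compound 4 is recorded with a limit, > 1000 nM, and not with a number. Even as a limit this gives the position its first readable comparison: with tert-butyl in place of ethyl on the aromatic carbon next to the ring nitrogen and next to the ring oxygen, the record shows an at least 7.1-fold higher number from compound 1 to compound 4 (0.85 log units; beyond the scatter), so the ethyl of compound 1 cannot be exchanged for tert-butyl at this carbon without a loss in this assay. Within the data shown here, the change from cyclohexyl to tert-butyl itself cannot be read, as compound 3 has no number and compound 4 has only a limit, and compound 1 remains the only one of the four compounds with a measured value.

The compounds shown leave open how far beyond its limit compound 4 lies, and whether it would give a number at all. They also leave open where a methyl, an isopropyl or a longer chain such as n-propyl would fall at this carbon relative to the ethyl of compound 1 and to tert-butyl.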